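The source may report more compounds than this note shows. Statements on the series, on what has been measured and on what is new or still open speak of the compounds shown alone.

Compound 1 (`COc1ccc(NC(=O)Nc2nc(Sc3c[nH]c4ccccc34)cc(N3CCCCC3)n2)cc1`) gives 13500 nM in a functional assay on A549 cells (Homo sapiens) for inhibition, with a stated time of 72 h; on this read-out higher numbers stand for weaker inhibition and lower numbers for stronger inhibition.
Compound 2 (`O=C(Nc1ccc(Cl)cc1)Nc1nc(Sc2c[nH]c3ccccc23)cc(N2CCCC2)n1`) gives 6410 nM.
Compound 3 (`O=C(Nc1ccccc1)Nc1nc(Sc2c[nH]c3ccccc23)cc(N2CCCC2)n1`) gives 21200 nM.

Among these three numbers compound 2 stands lowest; compound 1 sits nearest to it and compound 3 furthest. Going by the values given here, the only single-point step in the set, a 3.3-fold higher number from compound 2 to compound 3 (0.52 log units; beyond the scatter), goes with hydrogen in place of chloro on an aromatic carbon and is a modest one.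

Compound 4 (`O=C(Nc1ccc(Cl)cc1)Nc1nc(Sc2c[nH]c3ccccc23)cc(N2CCCCC2)n1`) differs from compound 2 by piperidin-1-yl in place of pyrrolidin-1-yl on an aromatic carbon. The measured step concerns the chloro position and does not bear on this ring change. Compound 1 also carries piperidin-1-yl and gives a higher number than compound 2, but it differs from compound 2 in a second place as well, so its value is only a loose guide. A small rise or no step beyond the scatter is therefore expected in this assay. For compound 4 the expected step is a 1.4-fold higher number from compound 2 to compound 4 (0.15 log units; within the scatter). Compound 4 is estimated at 9000 nM, within 4000 nM to 22000 nM.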

Compound 4, half-maximal inhibitory concentration: 18600 nM
Estimate against measurement, compound 4: 2.1-fold (0.32 log units) below; measured number inside the range.
By their numbers in this assay, from the lowest: compound 2; then compounds 1, 4 and 3 (each within the scatter of the next).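

Going by these compounds alone, with the chloro group held fixed, piperidin-1-yl in place of pyrrolidin-1-yl at this position, next to the ring nitrogen, gives in this assay a 2.9-fold higher number from compound 2 to compound 4 (0.46 log units; beyond the scatter) and thus a first direct reading of this ring change, one beyond the scatter. With piperidin-1-yl held fixed, chloro in place of methoxy gives a 1.4-fold higher number from compound 1 to compound 4 (0.14 log units; within the scatter) and so does not separate these two groups when this ring is present, whereas the step from chloro to hydrogen with pyrrolidin-1-yl lay beyond the scatter. Nothing shown gives a reason for either result.

As far as these compounds go, whether a morpholin-4-yl ring or an open-chain dimethylamino group at this position would stay close to compound 2 or to compound 4 remains open. Also open, from the compounds shown here alone, is whether the ring step keeps its size with hydrogen or methoxy in place of chloro.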